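Three Analogues at the Limit and a Trifluoromethyl Newcomer

This account rests on a few compounds, and the source may have more. Where it says the series, first, only, none or still open, it means among the compounds named here.

Measured so far:
compound 1, `N#Cc1c(-c2ccccc2)c(C#N)c(=O)n(/N=C/c2cn(-c3ccccc3)nc2-c2ccccc2)c1N`: > 200 ug/mL
compound 2, `N#Cc1c(-c2ccc(O)cc2)c(C#N)c(=O)n(/N=C/c2cn(-c3ccccc3)nc2-c2ccccc2)c1N`: > 200 ug/mL
compound 3, `N#Cc1c(-c2ccc([N+](=O)[O-])cc2)c(C#N)c(=O)n(/N=C/c2cn(-c3ccccc3)nc2-c2ccccc2)c1N`: > 200 ug/mL

In an ADME assay on HeLa cells (Homo sapiens) for cytotoxicity, read by MTT assay (on this read-out lower numbers stand for stronger inhibition and higher numbers for weaker inhibition), compound 1 gives > 200 ug/mL, which is a limit of the assay and not a number. Compound 2 gives > 200 ug/mL, again a limit. Compound 3 gives > 200 ug/mL, also a limit. So compound 2 stands where every value so far stands: the limit of > 200 ug/mL in this assay, at which 3 of the 3 values shown sit.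

The three steps among these compounds, a step that the two limits leave unreadable from compound 1 to compound 2, a step that the two limits leave unreadable from compound 1 to compound 3 and a step that the two limits leave unreadable from compound 2 to compound 3, cannot be sized, since both ends of each sit at the limit.

Compound 4, `N#Cc1c(-c2ccccc2C(F)(F)F)c(C#N)c(=O)n(/N=C/c2cn(-c3ccccc3)nc2-c2ccccc2)c1N`, is not yet measured. Its difference from compound 2 is 2-(trifluoromethyl)phenyl in place of 4-hydroxyphenyl on an aromatic carbon. The measured steps bearing on this change in this assay are unreadable, so no direction or size can be drawn from them; all that is known is that three different substituents on this ring left every value at the limit.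

Compound 4 is therefore expected to sit at the limit as well, with a step of a number no higher from compound 2 to compound 4 (the limit leaves the size open) that is not readable. The estimate for compound 4 is 200 ug/mL, in a range from 100 ug/mL to 400 ug/mL.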

Compound 4, half-maximal inhibitory concentration: > 200 ug/mL
Compound 4 gave a limit, no number; the forecaster's own chance of this, stated with the estimate: 85%; the middle value lies on the limit itself.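

In this assay compound 4 gives > 200 ug/mL as a limit, not a number. None of the steps from compound 1, compound 2 or compound 3 to compound 4 can be read, because all four compounds stand at the same place: the limit of > 200 ug/mL in this assay, at which 4 of the 4 values shown sit.

The compounds shown leave open whether any of these changes on the ring alters cytotoxicity at all.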